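Phenylsulfonyl for 1-benzothiophen-3-yl at the assay limit

This account rests on a few compounds, and the source may have more. Where it says the series, first, only, none or still open, it means among the compounds named here.

Measured in an ADME assay on cells (Fibroblast, Gallus gallus) for cytotoxicity, read by CCK-8 assay, with a stated time of 48 h (a lower number here means that less compound is tolerated, a higher number that more compound is tolerated), with every entry a limit of the assay:
- compound 1 `CCC(CC)Oc1ccc(CN[C@H]2CC(C(=O)O)=C[C@@H](OC(CC)CC)[C@@H]2NC(C)=O)cc1` gives > 200000 nM
- compound 2 `CCC(CC)O[C@@H]1C=C(C(=O)O)C[C@H](NCc2ccc(SCC(C)C)cc2)[C@H]1NC(C)=O` gives > 200000 nM
- compound 3 `CCC(CC)O[C@@H]1C=C(C(=O)O)C[C@H](NCc2ccc(-c3csc4ccccc34)cc2)[C@H]1NC(C)=O` gives > 200000 nM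

Compound 3 gives > 200000 nM as a limit and not a number. It stands with the other two measured compounds, with the limit of > 200000 nM in this assay, at which 3 of the 3 values shown sit, as the whole of the evidence so far. Compound 4 `CCC(CC)O[C@@H]1C=C(C(=O)O)C[C@H](NCc2ccc(S(=O)(=O)c3ccccc3)cc2)[C@H]1NC(C)=O` carries phenylsulfonyl in place of 1-benzothiophen-3-yl on an aromatic carbon. Three measured exchanges of the same kind bear on this change: a step that the two limits leave unreadable from compound 1 to compound 2 and a step that the two limits leave unreadable from compound 1 to compound 3 and also a step that the two limits leave unreadable from compound 2 to compound 3 with no size to read in any of them. They give no direction, and none of the three compounds leaves the limit in this assay on exchange. The expected step is a step that the limit leaves unreadable from compound 3 to compound 4 with nothing beyond the scatter anticipated. For compound 4 the estimate is 250000 nM with an expected range of 120000 nM to 500000 nM and a further limit as the likely report.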

Compound 4, half-maximal cytotoxic concentration: > 200000 nM
Compound 4 was reported as a limit; the forecaster's own chance of this, stated with the estimate: 90%; the middle value is on the limit's open side.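

No step can be read among compound 1, compound 2, compound 3 and compound 4, as each is reported only as a limit in this assay: the limit of > 200000 nM in this assay, at which 4 of the 4 values shown sit.

The compounds shown leave open where any of the four would reach half-maximal cytotoxicity, and whether the exchanged groups differ at all.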